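This account rests on a few compounds, and the source may have more. Where it says the series, first, only, none or still open, it means among the compounds named here.

Measured compounds:
Compound 1, `CC#C[C@@H](CC(=O)O)c1ccc(OC[C@H]2COc3cc(Cl)ccc3O2)cc1`, gives 80% in a functional assay on HEK293 cells for agonist activity at Free fatty acid receptor 1 (Homo sapiens), read by fluorescence and calcium flux, with a stated time of 10 min; a lower number here means a smaller maximal response, a higher number a larger maximal response.
Compound 2, `CC#C[C@@H](CC(=O)O)c1ccc(OC[C@H]2COc3ccccc3O2)cc1`, gives 70% in this assay.

Only these two compounds have numbers here. Compound 2 stands next to compound 1, and the step of a number 10 percentage points lower from compound 1 to compound 2 (within the scatter) is within the scatter, so the two cannot be told apart on this read-out. The step from compound 2 to compound 3, `CC#C[C@@H](CC(=O)O)c1ccc(OC[C@H]2COc3ccc(Br)cc3O2)cc1`, is bromo in place of hydrogen on an aromatic carbon. Going by the values given here, the one measured step that bears on it is the halogen change from compound 1 to compound 2, a number 10 percentage points lower from compound 1 to compound 2 (within the scatter), which stayed within the scatter. A second halogen put in at another place on the same ring is therefore expected to leave this assay much where it is, with no step beyond the scatter in either direction. The expected step is a number 5 percentage points higher from compound 2 to compound 3 (within the scatter). For compound 3 the estimate is 75%, with a range from 60% to 90%.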

Compound 3, largest response reached (Emax), in percent of the reference or control that the assay uses: 69%
Beside the measured number, compound 3's estimate is 6 percentage points above it; the range from low to high includes it.
By their numbers in this assay, from the lowest: compounds 3, 2 and 1 (each within the scatter of the next, the first and the last beyond it).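

Bromo in place of hydrogen, on the aromatic carbon meta to a fused ring and para to a fused ring, gives a number 1 percentage points lower from compound 2 to compound 3 (within the scatter) in this assay, so hydrogen and bromo cannot be told apart at this place. Going by these compounds alone, the earlier pair spoke only for a chloro at another place on the same ring, so this is the first sign that a halogen at this second place also stays within the scatter. Nothing given here explains this result.

The compounds shown leave open whether a group of another kind at this place, such as an amine, a methoxy or a nitrile, would also stay within the scatter. They also leave open how much of each compound is needed to reach its maximal response.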